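A third isopropyl group on the shared core

A few compounds are considered here, and "the series" means these few. Any claim that something is new, unique, unknown or untested is made for them only; others in the source may bear on it.

Compound 1 `CC(C)c1ccc(C(=O)/C=C/C(=O)O)cc1`: 25700 nM
Compound 2 `CC(C)c1ccc(C(=O)/C=C/C(=O)O)c(C(C)C)c1`: 5360 nM

In a functional assay on LS174T cells (Homo sapiens) for inhibition, read by MTT assay, with a stated time of 72 h (a lower number here means a stronger inhibitor, a higher number a weaker inhibitor), compound 2, at 5360 nM, has the lower of the two numbers, and compound 1 gives 25700 nM. The change leading to compound 3 `CC(C)c1cc(C(C)C)c(C(=O)/C=C/C(=O)O)c(C(C)C)c1` is isopropyl in place of hydrogen on an aromatic carbon, an isopropyl in place of hydrogen on an aromatic carbon, ortho to a (2-carboxyethenyl)carbonyl group. Among the compounds with values here, one measured step bears on this change, the same replacement of hydrogen by isopropyl: a 4.8-fold lower number from compound 1 to compound 2 (0.68 log units; beyond the scatter). That step lies beyond the scatter, but it is a single precedent, and the data do not show whether a further isopropyl would repeat it. A smaller step in the same direction is therefore expected, and the expected step is a 2.1-fold lower number from compound 2 to compound 3 (0.33 log units; beyond the scatter). For compound 3 the estimated value is 2500 nM, with an expected range from 800 nM to 7000 nM.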

Compound 3, half-maximal inhibitory concentration: 8280 nM
The estimate for compound 3 lay 3.3-fold (0.52 log units) below the measured number; measured number outside the range, above it.
By their numbers in this assay, from the lowest: compounds 2 and 3 (each within the scatter of the next); then compound 1.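

At this position, ortho to a (2-carboxyethenyl)carbonyl group and meta to two isopropyl groups, isopropyl in place of hydrogen gives a 1.5-fold higher number from compound 2 to compound 3 (0.19 log units; within the scatter) in this assay, so compound 2 and compound 3 cannot be told apart in this assay. The same replacement at the earlier position gave a 4.8-fold lower number from compound 1 to compound 2 (0.68 log units; beyond the scatter), which shows that the step beyond the scatter did not recur with this further isopropyl. No measurement shown here accounts for the contrast between the two steps.

Going by these compounds, whether a methyl, a hydroxyl or an amine in place of this hydrogen would separate from compound 2 in this assay remains open. The compounds shown also leave open whether isopropyl at this position would give the same result on a core lacking the two existing isopropyl groups.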